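Replacing nitro with methylamino: working notes on compound 3

This account rests on a few compounds, and the source may have more. Where it says the series, first, only, none or still open, it means among the compounds named here.

Measured so far:
- compound 1 `CC(C)Cn1c(SCc2ccccc2)nc(N)cc1=O` gives 68000 nM in growth inhibition
- compound 2 `COc1cc(OC)n2cc(-c3ccc([N+](=O)[O-])cc3)nc2n1` gives 70600 nM in growth inhibition

In a functional assay on LoVo cells (Homo sapiens) for antiproliferative activity, read by MTT assay, with a stated time of 72 h (on this read-out higher numbers stand for weaker inhibition of growth and lower numbers for stronger inhibition of growth), compound 2 at 70600 nM and compound 1 at 68000 nM lie within the scatter of each other, so compound 2 holds no separate rank. Compound 3 `CNc1ccc(-c2cn3c(OC)cc(OC)nc3n2)cc1` keeps the core of compound 2 and has methylamino in place of nitro on an aromatic carbon, para to a large group (methylamino in place of nitro on an aromatic carbon). Within the data shown here, no measured step exists to calibrate this change, so the expectation rests on the structural change alone, with compound 2 at 70600 nM as the only anchor. A moderate move towards stronger inhibition of growth is expected in this assay (a 2.4-fold lower number from compound 2 to compound 3 (0.37 log units; beyond the scatter)), although a result within the scatter would not surprise. The estimated value of compound 3 is 30000 nM (expected range 8000 nM to 100000 nM).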

Compound 3, concentration for 50% growth inhibition: > 100000 nM
Compound 3 ended at the assay's limit (the forecaster's own chance of this, stated with the estimate: 15%); middle value at least 3.3-fold (0.52 log units) from the limit.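

In this assay, methylamino in place of nitro on an aromatic carbon, para to a large group, gives an at least 1.4-fold higher number from compound 2 to compound 3 (0.15 log units; that floor lies within the scatter). The value of compound 3 is a limit and not a number, so this step has only a floor: the limit of > 100000 nM in this assay, at which 1 of the 3 values shown sits. Among these compounds, this is the first measured step at this position, and it shows that the change brings no lower number than that of compound 2, though the floor alone does not separate the two compounds.

The compounds shown leave open how a primary amine, a carboxylic acid or a longer chain on the same aromatic carbon would read, and whether any group there gives a lower number than nitro. From the compounds shown here alone, how far compound 3 lies past the limit also stays open.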